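Adding a Second Chloro to the Shared Core

The source may hold more compounds than are shown below. What is called first, only, known or untested is meant among the compounds shown, and "the series" means these compounds.

Compound 1 `ClCc1ccc(Cn2cnc3c(Cl)ncnc32)cc1` was tested in a functional assay on MDA-MB-231 cells (Homo sapiens) for cytotoxicity, read by sulforhodamine B assay, with a stated time of 48 h (on this read-out lower numbers stand for stronger inhibition of growth and higher numbers for weaker inhibition of growth), where compound 1 gives 1770 nM. Compound 2 `ClCc1cccc(Cn2cnc3c(Cl)nc(Cl)nc32)c1` gives 1950 nM in this assay; the two numbers sit within the usual scatter of each other, so neither stands apart. Compound 3 `ClCc1ccc(Cn2cnc3c(Cl)nc(Cl)nc32)cc1` has not yet been measured. It differs from compound 1 by chloro in place of hydrogen on an aromatic carbon. For the measured compounds named here, no pair of measured compounds shows this change alone, so the step is expected to be small, probably none beyond the scatter, as a 1.1-fold lower number from compound 1 to compound 3 (0.04 log units; within the scatter) expresses. Compound 3 is therefore estimated at 1600 nM, with a range from 700 nM to 3600 nM.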

Compound 3, concentration for 50% growth inhibition: 1820 nM
Compound 3: the middle estimate sits 1.1-fold (0.06 log units) below what was measured; the measured number falls inside the stated range.
By their numbers in this assay, from the lowest: compounds 1, 3 and 2 (each within the scatter of the next).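

In this assay, chloro in place of hydrogen on an aromatic carbon, between two ring nitrogen atoms, gives a 1.0-fold higher number from compound 1 to compound 3 (0.01 log units; within the scatter). For the compounds shown here, this is the first view of this change alone, and at this position the added chloro produces no step beyond the scatter. Nothing measured here bears on why the step is so small.

On these data alone, whether an amine or a methoxy group at this same position would give a step beyond the scatter remains open. So does the effect of a hydroxymethyl group in place of the chloromethyl group.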